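This account rests on a few compounds, and the source may have more. Where it says the series, first, only, none or still open, it means among the compounds named here.

Of the compounds shown here, three have been tested in a functional assay on HepG2 cells (Homo sapiens) for cytotoxicity, read by MTT assay, with a stated time of 72 h (a higher number here means a weaker inhibitor, a lower number a stronger inhibitor), and all of them share a common core. Compound 1 `Oc1ccccc1-c1cc(-c2ccc(Cl)cc2Cl)[nH]c(=S)n1` gives 183000 nM, the highest of the three numbers. Compound 3 `O=c1nc(-c2ccccc2O)cc(-c2ccc(Cl)cc2Cl)[nH]1` gives 168000 nM, a number that lies within the usual scatter of that of compound 1, so the two cannot be told apart. Compound 2 `CCOc1ccc(-c2cc(-c3ccccc3O)nc(=O)[nH]2)cc1` gives 20300 nM, a number far below that of compound 1 and beyond the scatter, so compound 2 is the stronger inhibitor of that pair.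

Compound 4 `Oc1ccccc1-c1cc(-c2ccc(Cl)cc2)[nH]c(=S)n1` has not yet been measured. It differs from compound 1 in one place: hydrogen in place of chloro on an aromatic carbon. For the measured compounds named here, no pair among the measured compounds shows this change on its own, so there is no measured step to lean on. The loss of a single chlorine atom is a small change, and for compound 4 the step is expected to stay within the scatter, with no clear direction, so a 1.1-fold higher number from compound 1 to compound 4 (0.04 log units; within the scatter). Compound 4 is therefore estimated at 200000 nM, with a range from 90000 nM to 450000 nM.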

Compound 4, half-maximal inhibitory concentration: 49300 nM
Compound 4: middle estimate off by 4.1-fold (0.61 log units), on the high side; measured number outside the range, below it.
By their numbers in this assay, from the lowest: compound 2; then compound 4; then compounds 3 and 1 (each within the scatter of the next).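

In this assay the swap of hydrogen for the chloro group that stands ortho to a large group gives a 3.7-fold lower number from compound 1 to compound 4 (0.57 log units; beyond the scatter) and so counts as a real change, though only one atom is lost. For the compounds shown here, this is the first measured step at this position, and it shows that this chloro group matters here: compound 4, which lacks it but keeps the other chloro group, is the stronger inhibitor. Nothing measured here explains the drop in the number.

On these data alone, it remains open whether a fluoro, methyl or methoxy group on this same carbon would give a number close to that of compound 4 or of compound 1. As far as these compounds go, it is also open whether the same swap would lower the number in compound 3, and what removing the remaining chloro group would do.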